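Unmeasured 2-chlorophenyl analogue in a three-compound series

The source may report more compounds than this note shows. Statements on the series, on what has been measured and on what is new or still open speak of the compounds shown alone.

Measured so far in a functional assay, with a stated time of 20 min, tested at 10 uM; on this read-out lower numbers stand for a weaker effect and higher numbers for a stronger effect at the one concentration tested:
compound 1 `COc1cc(/C=C/C(=O)C2=C(/C=C/c3ccc(O)c(OC)c3)NC(=O)NC2c2ccccc2)ccc1O`, 20%
compound 2 `COc1cc(/C=C/C(=O)C2=C(/C=C/c3ccc(O)c(OC)c3)NC(=O)NC2c2ccc(C)cc2)ccc1O`, 23.9%
compound 3 `COc1cc(/C=C/C(=O)C2=C(/C=C/c3ccc(O)c(OC)c3)NC(=O)NC2c2ccc(N(C)C)cc2)ccc1O`, 69.9%

Compound 3 stands highest of the three numbers in this assay ; its steps to compound 2 and to compound 1 are both beyond the scatter, and the step of a number 3.9 percentage points higher from compound 1 to compound 2 (within the scatter) is within the scatter, so compounds 1 and 2 are not ordered against each other.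

Compound 4 `COc1cc(/C=C/C(=O)C2=C(/C=C/c3ccc(O)c(OC)c3)NC(=O)NC2c2ccccc2Cl)ccc1O` has not yet been measured. Its change from compound 3: 2-chlorophenyl in place of 4-(dimethylamino)phenyl on a saturated ring carbon.

For the measured compounds named here, two measured steps bear on this change, since each of them installs the group that now leaves: a number 49.9 percentage points higher from compound 1 to compound 3 (beyond the scatter) and a number 46 percentage points higher from compound 2 to compound 3 (beyond the scatter). Both are large and both run upward when the dimethylamino group enters, while the hydrogen and methyl variants sit close together at the low end. Going by the values given here, removing the dimethylamino group is therefore expected to undo most of that rise, and the entering 2-chlorophenyl has no measured counterpart, so nothing argues for a number near compound 3. The expected step is a number 44.9 percentage points lower from compound 3 to compound 4 (beyond the scatter), downward and beyond the scatter.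

For compound 4 the estimate in this assay is 25%, with a range from 10% to 45%.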

Compound 4, a percentage reported as activity, at one concentration (the size of the read-out at that concentration, not a potency): 23%
Compound 4: middle estimate off by 2 percentage points, on the high side; low and high end bracket the measured number.
By their numbers in this assay, from the lowest: compounds 1, 4 and 2 (each within the scatter of the next); then compound 3.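

In this assay, the exchange on the saturated ring carbon gives a number 46.9 percentage points lower from compound 3 to compound 4 (beyond the scatter), so the high number of compound 3 does not carry over once 4-(dimethylamino)phenyl gives way to 2-chlorophenyl. The chloro group makes no difference that can be read against the plain phenyl, with a number 3 percentage points higher from compound 1 to compound 4 (within the scatter), and 2-chlorophenyl cannot be told apart from 4-methylphenyl, with a number 0.9 percentage points lower from compound 2 to compound 4 (within the scatter). Phenyl, 4-methylphenyl and 2-chlorophenyl now form one group within the scatter, 4-(dimethylamino)phenyl alone stands apart from all three at this position, and no measurement at hand accounts for that separation.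

As far as these compounds go, it remains open whether the high number belongs to the dimethylamino group specifically or would also appear with a primary amino group, a diethylamino group or a methoxy group on the phenyl ring. Also open, from the compounds shown here alone, are whether 4-chlorophenyl would join the low group alongside 2-chlorophenyl, and how these compounds would compare over a range of concentrations, as the single-concentration read-out gives no potency.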